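Notes on an aryl swap at the sulfonyl sulfur

The compounds below may be only part of what the source reports. "The series", "measured", "known", "first", "only" and "open" are said of these compounds alone.

Compound 1 `CCCCCCCCCCCCCCNC(=O)[C@@H](NC(=O)c1cc2ccccc2o1)[C@@H](C)O` gives 14200 nM in a functional assay on SiHa cells (Homo sapiens) for cytotoxicity, read by MTT assay, with a stated time of 48 h; a higher number here means a weaker inhibitor, a lower number a stronger inhibitor. Compound 2 `CCCCCCCCCCCCCCNC(=O)[C@@H](NS(=O)(=O)c1ccc(C)cc1)[C@@H](C)O` gives 19200 nM and compound 3 `CCCCCCCCCCCCCCNC(=O)[C@@H](NS(=O)(=O)c1cccs1)[C@@H](C)O` gives 20400 nM in this assay. Compound 3 stands together with the other two: a 1.4-fold higher number from compound 1 to compound 3 (0.16 log units; within the scatter) and a 1.1-fold higher number from compound 2 to compound 3 (0.03 log units; within the scatter), as does a 1.4-fold higher number from compound 1 to compound 2 (0.13 log units; within the scatter), so the three numbers cannot be told apart. Compound 4 `CCCCCCCCCCCCCCNC(=O)[C@@H](NS(=O)(=O)c1ccc2ccccc2c1)[C@@H](C)O` differs from compound 3 by naphthalen-2-yl in place of thiophen-2-yl on a sulfonyl sulfur. Within the data shown here, the one measured step at the same place, a 1.1-fold higher number from compound 2 to compound 3 (0.03 log units; within the scatter), bears directly on this change and stayed within the scatter; the swaps on the amine nitrogen likewise moved nothing beyond it. No step beyond the scatter is expected in this assay. Compound 4 is thus estimated at 20000 nM, with a range from 8000 nM to 50000 nM. The expected step is a 1.0-fold lower number from compound 3 to compound 4 (0.01 log units; within the scatter).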

Compound 4, half-maximal inhibitory concentration: 11100 nM
Beside the measured number, compound 4's estimate is 1.8-fold (0.26 log units) above it, and the stated range covers the measured number.
By their numbers in this assay, from the lowest: compounds 4, 1, 2 and 3 (each within the scatter of the next).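

On a sulfonyl sulfur, naphthalen-2-yl, with 10 heavy atoms in 2 six-membered aromatic rings, still gives no separable change in this assay: a 1.8-fold lower number from compound 3 to compound 4 (0.26 log units; within the scatter) and a 1.7-fold lower number from compound 2 to compound 4 (0.24 log units; within the scatter) are the two steps. The three sulfonyl aryl groups in compounds 2, 3 and 4 therefore cannot be told apart at this position, even with 10 heavy atoms in naphthalen-2-yl against 5 in thiophen-2-yl. No measured data accompany this result to explain it. Open, going by these compounds, is whether an amine or a carboxylic acid on that aryl group, or a shorter chain on the amide nitrogen, would give a step beyond the scatter.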